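The compounds below may be only part of what the source reports. "The series", "measured", "known", "first", "only" and "open" are said of these compounds alone.

Three measured compounds share one core. Compound 1 is `CC(=O)OCc1ccc2oc(=O)c(C(=O)Oc3cccc(Cl)c3)cc2c1`, compound 2 is `CC(=O)OCc1ccc2oc(=O)c(C(=O)Oc3cccc(Br)c3)cc2c1` and compound 3 is `CC(=O)OCc1ccc2oc(=O)c(C(=O)Nc3cccc(Cl)c3)cc2c1`. In a functional assay on HT-1080 cells (Homo sapiens), read by transwell migration, with a stated time of 24 h, tested at 0.1 uM (a higher number here means a weaker effect of the compound at the concentration tested, a lower number a stronger effect), compound 1 gives 95.2%, compound 2 gives 39.5% and compound 3 gives 79.6%. Compound 2 therefore stands lowest of the three, which here means the strongest effect: a number 55.7 percentage points lower from compound 1 to compound 2 (beyond the scatter), while a number 15.6 percentage points lower from compound 1 to compound 3 (beyond the scatter) and a number 40.1 percentage points higher from compound 2 to compound 3 (beyond the scatter).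

Compound 4, `CC(C)C(=O)OCc1ccc2oc(=O)c(C(=O)Oc3cccc(Br)c3)cc2c1`, is not yet measured. It differs from compound 2 in one place: isopropyl in place of methyl on a carbonyl carbon. Both measured steps touch other parts of the molecule, the halogen on the aromatic ring and the link at the carbonyl carbon carrying the halogenated ring, so none of them bears directly on this change, and nothing measured shows how this assay answers to a change at this carbonyl carbon. The expectation is therefore a step within the scatter, with compound 4 staying close to compound 2, which the estimate puts at a number 5.5 percentage points higher from compound 2 to compound 4 (within the scatter). Compound 4 is estimated at 45%, between 25% and 70%.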

Compound 4, a percentage reported as activity, at one concentration (the size of the read-out at that concentration, not a potency): 54.4%
Estimate against measurement, compound 4: 9.4 percentage points below; the range from low to high includes it.
By their numbers in this assay, from the lowest: compound 2; then compound 4; then compound 3; then compound 1.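

Among the compounds shown here, the acetoxymethyl group was unchanged in the earlier compounds, and this step shows that this assay responds to a change there: with isopropyl in place of methyl on this carbonyl carbon, the effect weakens (a number 14.9 percentage points higher from compound 2 to compound 4 (beyond the scatter)). The printed size of this step is modest, whereas bromo in place of chloro on the aromatic carbon gave a large one (a number 55.7 percentage points lower from compound 1 to compound 2 (beyond the scatter)), so this site is not silent, although its step is the smaller of the two. No measured property of these compounds explains the change from methyl to isopropyl.

A single step cannot show whether a longer chain, a phenyl ring or an amine on this carbonyl carbon would weaken the effect further or restore it. From the compounds shown here alone, it also remains open whether isopropyl would produce a similar step in compound 1 or compound 3, which carry chloro rather than bromo.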